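The compounds below may be only part of what the source reports. "The series", "measured", "known", "first", "only" and "open" are said of these compounds alone.

Working notes on the triazole series against a functional assay on LoVo cells (Homo sapiens) for inhibition, read by MTT assay, with a stated time of 24 h; on this read-out higher numbers stand for weaker inhibition and lower numbers for stronger inhibition. Compound 1 `CC1(C)[C@H]2CC[C@]1(C)N(Cc1cn(-c3ccccc3C#N)nn1)C(=O)C2` gives 140 nM in this assay. Compound 2 `CC1(C)[C@H]2CC[C@]1(C)N(Cc1cn(-c3ccccc3Cl)nn1)C(=O)C2` gives 190 nM and so holds the highest number of the three measured compounds; the nearest is compound 1, and the step of a 1.4-fold higher number from compound 1 to compound 2 (0.13 log units; within the scatter) is within the scatter, so the two are not separated. Compound 3 `CC1(C)[C@H]2CC[C@]1(C)N(Cc1cn(-c3cccc(Br)c3)nn1)C(=O)C2` gives 30 nM, the lowest number of the set, reached through a 6.3-fold lower number from compound 2 to compound 3 (0.80 log units; beyond the scatter) and a 4.7-fold lower number from compound 1 to compound 3 (0.67 log units; beyond the scatter), both modest but beyond the scatter.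

Compound 4 `CC1(C)[C@H]2CC[C@]1(C)N(Cc1cn(-c3ccc(Cl)cc3)nn1)C(=O)C2` is not yet measured in this assay. Compared with compound 2, the change is 4-chlorophenyl in place of 2-chlorophenyl on an aromatic nitrogen. For the measured compounds named here, the step that bears on it most directly is a 6.3-fold lower number from compound 2 to compound 3 (0.80 log units; beyond the scatter), where a halogen on the aryl attached to the ring nitrogen was placed differently and the number fell; no measured step carries a 4-substituted aryl, so the carry-over is uncertain. A lower number of modest size is therefore expected for compound 4, as a 2.4-fold lower number from compound 2 to compound 4 (0.38 log units; beyond the scatter), short of what compound 3 shows. The estimate for compound 4 is 80 nM, with a range from 25 nM to 250 nM.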

Compound 4, half-maximal inhibitory concentration: 160 nM
For compound 4 the middle estimate is 2.0-fold (0.30 log units) below the measured one; low and high end bracket the measured number.
By their numbers in this assay, from the lowest: compound 3; then compounds 1, 4 and 2 (each within the scatter of the next).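

Moving the chlorine from 2-chlorophenyl to 4-chlorophenyl on the aromatic nitrogen gives no separation in this assay, with a 1.2-fold lower number from compound 2 to compound 4 (0.07 log units; within the scatter). Compound 4 also stays unseparated from the 2-cyanophenyl compound, with a 1.1-fold higher number from compound 1 to compound 4 (0.06 log units; within the scatter), while the step to the 3-bromophenyl compound reads a 5.3-fold higher number from compound 3 to compound 4 (0.73 log units; beyond the scatter), so among these compounds only compound 3 stands apart from the other three. Nothing at hand gives a reason for these numbers.

Compound 3 differs from compound 4 in both the halogen and its place on the aryl, so the compounds shown do not tell which of the two goes with the lower number of compound 3. A 3-chlorophenyl group and a 4-bromophenyl group on the same nitrogen would separate these two changes.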